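This account rests on a few compounds, and the source may have more. Where it says the series, first, only, none or still open, it means among the compounds named here.

Measured in a functional assay on HepG2 cells (Homo sapiens) for antiproliferative activity, read by sulforhodamine B assay, with a stated time of 48 h; on this read-out lower numbers stand for stronger inhibition and higher numbers for weaker inhibition:
- compound 1 `COc1cc(OC)c(C=C(C(=O)/C=C/c2cccc(OC)c2OC)C(=O)/C=C/c2cccc(OC)c2OC)c(OC)c1`: 300 nM
- compound 2 `COc1cccc(C=C(C(=O)/C=C/c2cccc(OC)c2OC)C(=O)/C=C/c2cccc(OC)c2OC)c1OC`: 230 nM

Compound 2 gives 230 nM, and it cannot be ranked against compound 1, since the two values lie within the usual scatter of each other. The next compound is compound 3 `COc1cc(C=C(C(=O)/C=C/c2cccc(OC)c2OC)C(=O)/C=C/c2cccc(OC)c2OC)cc(Br)c1O`, and the change from compound 2 is 3-bromo-4-hydroxy-5-methoxyphenyl in place of 2,3-dimethoxyphenyl on a double-bonded chain carbon bound to a double-bonded chain carbon. In words, this is 3-bromo-4-hydroxy-5-methoxyphenyl in place of 2,3-dimethoxyphenyl on a double-bonded chain carbon bound to a double-bonded chain carbon.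

Going by the values given here, only one measured step bears on this, a 1.3-fold lower number from compound 1 to compound 2 (0.12 log units; within the scatter), which alters the group at the same place. That step is small, but neither measured compound carries bromine or a hydroxy group, so it is only a weak guide. No step beyond the scatter is therefore expected in this assay, and no direction can be favoured. The expected step is a 1.1-fold higher number from compound 2 to compound 3 (0.04 log units; within the scatter). For compound 3 the estimated value is 250 nM, with an expected range of 80 nM to 800 nM.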

Compound 3, half-maximal inhibitory concentration: 240 nM
Compound 3: middle estimate off by 1.0-fold (0.02 log units), on the high side, and the stated range covers the measured number.
By their numbers in this assay, from the lowest: compounds 2, 3 and 1 (each within the scatter of the next).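

This position now takes a group carrying bromine and a hydroxy group, neither of which appears in compound 1 or compound 2, and the number stays within the scatter. Measured in this assay the exchange gives (a 1.0-fold higher number from compound 2 to compound 3 (0.02 log units; within the scatter)) and, against the trimethoxyphenyl group, gives (a 1.3-fold lower number from compound 1 to compound 3 (0.10 log units; within the scatter)), so the three different phenyl groups at this place cannot be ranked, although the entering group adds a hydrogen-bond donor that the leaving group lacks. No supporting measurement is available to explain why these numbers stay so close.

Going by these compounds, all three compounds carry a substituted phenyl ring here, so it remains open whether a group of another kind, such as a carboxylic acid or a dimethylamino group, would keep the number in this range. On these data alone, it is also open whether changing the two 2,3-dimethoxyphenyl groups at the other end of the chains would matter more.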